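This account rests on a few compounds, and the source may have more. Where it says the series, first, only, none or still open, it means among the compounds named here.

Measured so far:
- compound 1 `O=C(Nc1ccc(Oc2ccnc3[nH]ccc23)cc1)c1cc2cccnc2n(-c2ccc(F)c(Cl)c2)c1=O`: "not determined" (no result reported) in a functional assay on U-87MG ATCC cells for antiproliferative activity against U-87 MG (Homo sapiens), read by MTT assay, with a stated time of 72 h; on this read-out higher numbers stand for weaker inhibition and lower numbers for stronger inhibition
- compound 2 `O=C(Nc1ccc(Oc2ccnc3[nH]ccc23)cc1)c1cc2cccnc2n(-c2ccc(C(F)(F)F)cc2Cl)c1=O`: 6030 nM

Compound 1 stands on no number in this assay; only compound 2, which shares the core, gives a value in this assay. The change from compound 1 to compound 3 `O=C(Nc1ccc(Oc2ccnc3[nH]ccc23)c(F)c1)c1cc2cccnc2n(-c2ccc(F)c(Cl)c2)c1=O` is fluoro in place of hydrogen on an aromatic carbon. Going by the values given here, with no measured step between two compounds, the expected size of the step in this assay is not fixed by data; no shift beyond the scatter is assumed in either direction. Compound 3 is expected to give about 4000 nM in this assay, within a range of 1000 nM to 15000 nM.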

Compound 3, half-maximal inhibitory concentration: 5230 nM
Estimate against measurement, compound 3: 1.3-fold (0.12 log units) below, within the range that was stated.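

Going by these compounds alone, no step from compound 1 to compound 3 can be read in this assay: compound 1 carries no number there. On these data alone, whether fluoro in place of hydrogen shifts inhibition beyond the scatter stays open. Nothing available bears on the result.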